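The compounds below may be only part of what the source reports. "The series", "measured", "known", "first", "only" and "open" are said of these compounds alone.

Measured in a functional assay on HeLa cells (Homo sapiens) for inhibition, with a stated time of 72 h; on this read-out lower numbers stand for stronger inhibition and higher numbers for weaker inhibition:
- Compound 1 `C=CCOC(=O)N1CCC(C(=O)NCc2ccccc2)(N(Cc2ccccc2)C(=O)[C@H](CC(=O)OC)NC(=O)OC(C)(C)C)CC1`: 107000 nM
- Compound 2 `CC(C)(C)N(CC(=O)N(Cc1ccccc1)C1(C(=O)NCc2ccccc2)CCN(Cc2ccccc2)CC1)C(=O)O`: 19000 nM
- Compound 3 `CC[C@@H](C)[C@H](NC(=O)OC(C)(C)C)C(=O)N(C1CC1)C1(C(=O)NC(C)(C)C)CCN(Cc2ccccc2)CC1`: > 250000 nM, a limit and not a number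

Of the two actual numbers, compound 1 has the higher at 107000 nM, and compound 2 has the lower at 19000 nM, a gap beyond the usual scatter.

Compound 4 `COC(=O)C[C@H](NC(=O)OC(C)(C)C)C(=O)N(Cc1ccccc1)C1(C(=O)NCc2ccccc2)CCNCC1` differs from compound 1 in one place: hydrogen in place of allyloxycarbonyl on an amine nitrogen in a ring. In words, this is hydrogen in place of allyloxycarbonyl on an amine nitrogen in a ring. Among the measured compounds shown here, no measured pair isolates this change, so the guidance is thin. Compound 2, which lacks allyloxycarbonyl, gives 19000 nM, and this hints at a lower number. Compound 3 also lacks that group and gives > 250000 nM, which is a limit. Compound 3 therefore goes against that hint.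

A small move towards a lower number is expected, perhaps none beyond the scatter, and the estimated change is a 1.5-fold lower number from compound 1 to compound 4 (0.18 log units; within the scatter). For compound 4 the estimate is 70000 nM, with an expected range of 20000 nM to 220000 nM.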

Compound 4, half-maximal inhibitory concentration: > 167000 nM
Compound 4 ended at the assay's limit; the forecaster's own chance of this, stated with the estimate: 25%; middle value at least 2.3-fold (0.37 log units) away from the limit.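

The replacement of allyloxycarbonyl by hydrogen is the first change shown that isolates the group on this amine nitrogen in a ring, and in this assay it reads as an at least 1.5-fold higher number from compound 1 to compound 4 (0.19 log units; that floor lies within the scatter). Compound 4 gives a limit and not a number: the limit of > 167000 nM in this assay, at which 1 of the 4 values shown sits. Removing allyloxycarbonyl from this nitrogen therefore brings no move towards stronger inhibition, though how far the number rises, if it rises at all, stays unsettled.

The compounds shown leave open the true value of compound 4 and whether any other group on this nitrogen would give stronger inhibition than allyloxycarbonyl does. A methyl group, an acetyl group or a longer carbamate chain at this place, with the rest of compound 1 kept, would test that.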